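The compounds below may be only part of what the source reports. "The series", "measured", "known", "first", "only" and "open" are said of these compounds alone.

In an ADME assay on HEK293 cells (Homo sapiens) for cytotoxicity, read by MTT assay (on this read-out lower numbers stand for stronger inhibition and higher numbers for weaker inhibition), three members of this series have been measured so far. Compound 1 `O=c1n(Cc2cn(Cc3cc4ccc(Cl)cc4nc3Cl)nn2)cnn1-c1ccccc1` gives 869 ug/mL. Compound 2 `Cc1cccc2cc(Cn3cc(Cn4cnn(-c5ccccc5)c4=O)nn3)c(Cl)nc12` has a core that differs from that of compound 1 in a way that is not broken down here; in this assay compound 2 gives 729 ug/mL, and these two numbers lie within the scatter of each other. Compound 3 `COc1ccc(-n2ncn(Cc3cn(Cc4cc5ccc(Cl)cc5nc4Cl)nn3)c2=O)cc1` gives 1470 ug/mL in this assay. Compound 3 is derived from compound 1 by one change, (methoxy in place of hydrogen on an aromatic carbon), and that change brought a 1.7-fold higher number from compound 1 to compound 3 (0.23 log units; within the scatter).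

Compound 4 `COc1ccc(-n2ncn(Cc3cn(Cc4cc5cccc(C)c5nc4Cl)nn3)c2=O)cc1` has not yet been measured in this assay. It stands to compound 2 as compound 3 stands to compound 1: the change from compound 2 to compound 4 is methoxy in place of hydrogen on an aromatic carbon, the same change made on the core of compound 2. Among the four compounds this change occurs twice in all.

Among the measured compounds shown here, the only measured instance of this change, from compound 1 to compound 3, stayed within the scatter, so the expectation for compound 4 rests on a single precedent. Compound 4 is expected to show a step of about a 1.5-fold higher number from compound 2 to compound 4 (0.18 log units; within the scatter) in this assay, because the same change gave a 1.7-fold higher number from compound 1 to compound 3 (0.23 log units; within the scatter). On that basis compound 4 is estimated at 1100 ug/mL in this assay, with a range from 600 ug/mL to 2000 ug/mL.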

Compound 4, half-maximal inhibitory concentration: 586 ug/mL
For compound 4 the middle estimate is 1.9-fold (0.27 log units) above the measured one; measured number outside the range, below it.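

In this assay, the step from phenyl to 4-methoxyphenyl on the core of compound 2 comes to a 1.2-fold lower number from compound 2 to compound 4 (0.09 log units; within the scatter). Set beside the one earlier instance of this change, on the core of compound 1, the two steps cannot be told apart: the same change on two cores in this assay, a 1.7-fold higher number (0.23 log units; within the scatter) from compound 1 to compound 3 and a 1.2-fold lower number (0.09 log units; within the scatter) from compound 2 to compound 4, 2.1-fold (0.32 log units) apart, within the scatter of two such steps So far, on both cores, methoxy in place of hydrogen leaves the number within the scatter, and the two cores show no measurable difference in how the change carries over, but two pairs with steps this small show neither a real effect of the methoxy group nor any dependence on the core, and they say nothing about how the change would read on a third core.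

Going by these compounds, whether an amine or a carboxylic acid in place of the methoxy group on the phenyl ring would give a step beyond the scatter remains open, as does the same question for a longer chain such as ethoxy. All of these numbers also come from this assay alone, so whether the change carries from core to core in any other read-out is open too.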